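The compounds below may be only part of what the source reports. "The series", "measured", "known", "first", "only" and "open" are said of these compounds alone.

In a functional assay on thoracic aorta (Rattus norvegicus, strain Wistar), with a stated time of 15 min (a lower number here means that less compound is needed, a higher number that more compound is needed for the effect), compound 1 (`COc1ccc(Cl)cc1C(C)NC(=O)N(C)S(=O)(=O)c1ccc(C)cc1`) gives 13800 nM and compound 2 (`COc1ccc(Cl)cc1C(C)NC(=O)N(C)S(=O)(=O)c1ccccc1`) gives 7200 nM. Going by the values given here, the only measured step is a 1.9-fold lower number from compound 1 to compound 2 (0.28 log units; within the scatter), so these two compounds stand level on the data so far. Compound 3 (`COc1ccc(F)cc1C(C)NC(=O)N(C)S(=O)(=O)c1ccccc1`) keeps the rest of compound 2 and differs at a single place: fluoro in place of chloro on an aromatic carbon. Fluoro takes the place of chloro on an aromatic carbon, para to a methoxy group. Among the compounds with values here, no measured step makes this swap, so the evidence is indirect. The closest guide is the change from methyl to hydrogen on an aromatic carbon, which gave a 1.9-fold lower number from compound 1 to compound 2 (0.28 log units; within the scatter). On that weak basis, no shift beyond the scatter is expected in this assay. The expected step is a 1.3-fold higher number from compound 2 to compound 3 (0.10 log units; within the scatter). For compound 3 the estimated value is 9000 nM, with an expected range of 3000 nM to 27000 nM.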

Compound 3, half-maximal effective concentration: 10000 nM
For compound 3 the middle estimate is 1.1-fold (0.05 log units) below the measured one, within the range that was stated.
By their numbers in this assay, from the lowest: compounds 2, 3 and 1 (each within the scatter of the next).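

Going by these compounds alone, this is the first measured change at this position, on the six-membered aromatic ring of carbon only, para to a methoxy group; the earlier step concerned a methyl group elsewhere in the molecule. In this assay, fluoro in place of chloro gives a 1.4-fold higher number from compound 2 to compound 3 (0.14 log units; within the scatter), so the two compounds stand level and this exchange of one halogen for another makes no clear difference to the read-out. Nothing available offers an explanation for this result.

At this position the compounds shown cover only chloro and fluoro, so a single pair says little about how much the position can accept. On these data alone, whether a quite different group here, such as an amine, a carboxylic acid or a longer alkyl chain, would move the number beyond the scatter stays open.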